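Dimethylaminophenyl Variant in the Rat Paw Edema Test

A few compounds are considered here, and "the series" means these few. Any claim that something is new, unique, unknown or untested is made for them only; others in the source may bear on it.

Measured compounds:
- compound 1 `O=C1N=C(C2C(=O)c3ccccc3C2=O)CC(c2ccccc2[N+](=O)[O-])N1`: 11%
- compound 2 `COc1ccc(C2CC(C3C(=O)c4ccccc4C3=O)=NC(=O)N2)cc1`: 22%
- compound 3 `O=C1N=C(C2C(=O)c3ccccc3C2=O)CC(c2ccc(Cl)cc2)N1`: 15%

In a functional assay on the whole organism for inhibition, with Rattus norvegicus as the target, read by paw edema, with stated times of 30 min and 1 h, at a dose of 10 mg/kg by the oral route (on this read-out higher numbers stand for more inhibition at the one dose given (going by the name of the read-out) and lower numbers for less inhibition), compound 1 gives 11%, the smallest of the three numbers, though its gap to compound 3 lies within the scatter and only the gap to compound 2 lies beyond it. The two measured steps that start from compound 1 both exchange the 2-nitrophenyl group on the saturated ring carbon: a number 11 percentage points higher from compound 1 to compound 2 (beyond the scatter), while a number 4 percentage points higher from compound 1 to compound 3 (within the scatter). Between the two 4-substituted phenyl compounds a number 7 percentage points lower from compound 2 to compound 3 (within the scatter), so no order can be read there.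

Compound 4 `CN(C)c1ccc(C2CC(C3C(=O)c4ccccc4C3=O)=NC(=O)N2)cc1` is the next variant on the same saturated ring carbon: 4-(dimethylamino)phenyl in place of 2-nitrophenyl on a saturated ring carbon. Like the two measured steps it replaces 2-nitrophenyl with a phenyl bearing a group at the 4-position, and those steps gave a modest rise or none beyond the scatter. A rise of similar size is therefore expected, a number 9 percentage points higher from compound 1 to compound 4 (within the scatter). Compound 4 is estimated at 20% in this assay, with a range from 8% to 32%.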

Compound 4, a percentage reported as inhibition, in the whole organism at one dose (the size of the read-out at that dose, not a potency): 15%
Compound 4: the middle estimate sits 5 percentage points above what was measured; the measured number falls inside the stated range.
By their numbers in this assay, from the lowest: compounds 1, 3, 4 and 2 (each within the scatter of the next, the first and the last beyond it).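

In this assay, 4-(dimethylamino)phenyl in place of 2-nitrophenyl gives a number 4 percentage points higher from compound 1 to compound 4 (within the scatter) and so does not repeat the step beyond the scatter seen with 4-methoxyphenyl. Dimethylamino in place of chloro gives no change at the digits printed from compound 3 to compound 4 (within the scatter) and in place of methoxy gives a number 7 percentage points lower from compound 2 to compound 4 (within the scatter) and these three groups on the phenyl ring therefore cannot be put in any order at this position. No supporting measurement is available to explain these numbers.

The compounds shown leave open what an unsubstituted phenyl or 4-nitrophenyl would give on the same saturated ring carbon, so the effect of the nitro group cannot be separated from that of where it sits on the ring. A carboxylic acid on the phenyl ring also remains an open case.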